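One Stereocentre Inverted: From Compound 1 to Compound 3

The compounds below may be only part of what the source reports. "The series", "measured", "known", "first", "only" and "open" are said of these compounds alone.

Compound 1 `C[C@H](CSc1nonc1/C(=N/O)Nc1ccc(F)c(Br)c1)NC(=O)CS(N)(=O)=O`: 12 nM
Compound 2 `O=C(NCCSc1nonc1/C(=N/O)Nc1ccc(F)c(C(F)F)c1)C1CS(=O)(=O)C1`: 13 nM

Both compounds were tested in an assay for inhibition of Indoleamine 2,3-dioxygenase 1 (Homo sapiens), read by fluorescence, with a stated time of 24 h; a lower number here means a stronger inhibitor, a higher number a weaker inhibitor. Compound 1 gives 12 nM, the lowest of the two numbers, while compound 2 gives 13 nM, a gap within the scatter, so no order between them is claimed. Compound 3 `C[C@@H](CSc1nonc1/C(=N/O)Nc1ccc(F)c(Br)c1)NC(=O)CS(N)(=O)=O` awaits measurement. Compared with compound 1, (the two compounds have the same atoms and bonds and differ only in configuration as drawn: 1 of 2 stereo elements differ; a stereocentre at a saturated chain carbon is drawn R in compound 1 and S in compound 3). Going by the values given here, no step between measured compounds informs this change; a modest weakening in this assay is expected, though a step within the scatter cannot be excluded. Compound 3 is expected to give 30 nM, between 8 nM and 150 nM. That estimate corresponds to an expected step of a 2.5-fold higher number from compound 1 to compound 3 (0.40 log units; beyond the scatter).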

Compound 3, half-maximal inhibitory concentration: 19 nM
The estimate for compound 3 lay 1.6-fold (0.20 log units) above the measured number; measured number inside the range.
By their numbers in this assay, from the lowest: compounds 1, 2 and 3 (each within the scatter of the next).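

In this assay, inverting the stereocentre at the saturated chain carbon from R to S gives a 1.6-fold higher number from compound 1 to compound 3 (0.20 log units; within the scatter), so at this position the configuration as drawn makes no difference that can be told from the scatter. Going by these compounds alone, this is the first step that can be read at this carbon, and it isolates a single change: the fact that compounds 1 and 3 differ only in the configuration as drawn.

The compounds shown leave open whether the two configurations stay this close when an amine or a carboxylic acid replaces the sulfonamide. They also leave open whether that holds with a longer chain.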